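Removing One Methoxy Group: From Compound 2 to Compound 3

The source may report more compounds than this note shows. Statements on the series, on what has been measured and on what is new or still open speak of the compounds shown alone.

Compound 2 `COc1cc(C(=O)/C=C/c2cc(-c3cc(OC)c(OC)c(OC)c3)n[nH]2)cc(OC)c1OC` gives 2950 nM in a functional assay on MDA-MB-435 cells (Homo sapiens) for inhibition, read by sulforhodamine B assay, with a stated time of 48 h (a lower number here means a stronger inhibitor of growth, a higher number a weaker inhibitor of growth), the higher of the two numbers measured, though the gap to compound 1 `COc1ccc(C(=O)/C=C/c2cc(-c3cc(OC)c(OC)c(OC)c3)n[nH]2)cc1OC`, which gives 2710 nM, is within the scatter. Among the compounds with values here, the change now followed, (hydrogen in place of methoxy on an aromatic carbon), leads to compound 3 `COc1ccc(-c2cc(/C=C/C(=O)c3cc(OC)c(OC)c(OC)c3)[nH]n2)cc1OC` and reverses the only measured step. Because a 1.1-fold higher number from compound 1 to compound 2 (0.04 log units; within the scatter) stayed within the scatter, no shift beyond the scatter is expected in this assay. Compound 3 is therefore estimated at 2800 nM, within 1200 nM to 6500 nM. This expectation corresponds to a 1.1-fold lower number from compound 2 to compound 3 (0.02 log units; within the scatter).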

Compound 3, concentration for total growth inhibition: 4050 nM
Beside the measured number, compound 3's estimate is 1.4-fold (0.16 log units) below it; the range from low to high includes it.
By their numbers in this assay, from the lowest: compounds 1, 2 and 3 (each within the scatter of the next).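

In this assay the loss of this methoxy group, which sits ortho to a methoxy group and meta to a large group, gives a 1.4-fold higher number from compound 2 to compound 3 (0.14 log units; within the scatter). A second methoxy change, this time on the other six-membered aromatic ring of carbon only, thus also stays within the scatter. Nothing available bears on why this position responds so little.

The compounds shown leave open whether a hydroxyl, an amine or a fluorine on this aromatic carbon would move the number beyond the scatter. They also leave open whether removing both methoxy groups flanking this position would do so.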